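Aryl swap at the saturated ring carbon: compound 3 to 4

The compounds below may be only part of what the source reports. "The series", "measured", "known", "first", "only" and "open" are said of these compounds alone.

Measured so far:
compound 1 `N#CC1=C(N)N(c2ccc(S(N)(=O)=O)cc2)C2=C(C(=O)CCC2)C1c1ccccc1` gives 40% in a functional assay on Ehrlich cells (Mus musculus) for antiproliferative activity, read by trypan blue exclusion, with a stated time of 2 h, tested at 100 ug/mL; a higher number here means a stronger effect of the compound at the concentration tested, a lower number a weaker effect;
compound 2 `COc1ccccc1C1C(C#N)=C(N)N(c2ccc(S(N)(=O)=O)cc2)C2=C1C(=O)CCC2` gives 0%;
compound 3 `N#CC1=C(N)N(c2ccc(S(N)(=O)=O)cc2)C2=C(C(=O)CCC2)C1c1ccc(Cl)cc1Cl` gives 95%.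

Compound 3 stands highest of the three, above compound 1 by a number 55 percentage points higher from compound 1 to compound 3 (beyond the scatter) and above compound 2 by a number 95 percentage points higher from compound 2 to compound 3 (beyond the scatter). Compound 4 `N#CC1=C(N)N(c2ccc(S(N)(=O)=O)cc2)C2=C(C(=O)CCC2)C1c1ccco1` differs from compound 3 by furan-2-yl in place of 2,4-dichlorophenyl on a saturated ring carbon. Going by the values given here, both steps into compound 3 concern the group on this saturated ring carbon, and both were large gains; no step shows a furan-2-yl there. Removing the 2,4-dichlorophenyl is therefore expected to give a large step downward, estimated as a number 60 percentage points lower from compound 3 to compound 4 (beyond the scatter). For compound 4 an activity of 35% is expected, in the range 5% to 75%.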

Compound 4, a percentage reported as activity, at one concentration (the size of the read-out at that concentration, not a potency): 10%
Compound 4: the middle estimate sits 25 percentage points above what was measured; the range from low to high includes it.
By their numbers in this assay, from the lowest: compounds 2 and 4 (each within the scatter of the next); then compound 1; then compound 3.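

In this assay, a five-membered aromatic ring on this saturated ring carbon gives a number 85 percentage points lower from compound 3 to compound 4 (beyond the scatter) and a number 30 percentage points lower from compound 1 to compound 4 (beyond the scatter), so furan-2-yl keeps neither the level of 2,4-dichlorophenyl nor that of phenyl. Against 2-methoxyphenyl, the swap gives a number 10 percentage points higher from compound 2 to compound 4 (within the scatter), so two quite different groups here share a low read-out. No measurement shown accounts for these differences. The compounds shown leave open whether both chlorines are needed, which 4-chlorophenyl or 2-chlorophenyl would address. Also open, from the compounds shown here alone, is how thiophen-2-yl or a saturated cyclohexyl would behave at this carbon.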